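A few compounds are considered here, and "the series" means these few. Any claim that something is new, unique, unknown or untested is made for them only; others in the source may bear on it.

Measured compounds in a functional assay for antagonist activity at Neuropeptide Y receptor type 5 (Homo sapiens); on this read-out higher numbers stand for weaker inhibition and lower numbers for stronger inhibition:
compound 1 `O=C1O[C@]2(CC[C@H](CNc3cnn(-c4ccccc4F)c3)CC2)CN1c1cncnc1` gives 0.0398 nM
compound 2 `O=C1O[C@]2(CC[C@H](CNc3ccn(-c4ccccc4F)n3)CC2)CN1c1ccccn1` gives 0.0316 nM
compound 3 `Cc1cccc(-c2ccc(NC[C@H]3CC[C@]4(CC3)CN(c3cccnn3)C(=O)O4)nc2)n1` gives 0.251 nM

Compound 1 stands second highest of the three numbers. Its nearest neighbour is compound 2, whose number lies within the usual scatter of it, so no order between these two can be read. The furthest is compound 3, whose higher number lies beyond the scatter. Among the compounds with values here, compound 2 and compound 3 each differ from compound 1 in more than one place, so no single counted step exists among the measured compounds.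

Compound 4 `O=C1O[C@]2(CC[C@H](CNc3cnn(-c4ccccc4F)c3)CC2)CN1c1cccnc1` differs from compound 1 in one place: pyridin-3-yl in place of pyrimidin-5-yl on an amide-type nitrogen in a ring. Within the data shown here, nothing among the measured compounds isolates a change of this kind on that amide-type nitrogen, so the expectation rests on the small distance between compound 1 and compound 2. In this assay a step of no size beyond the scatter is expected for the change to compound 4, with at most a slight rise; the step expected from the estimate is a 1.3-fold higher number from compound 1 to compound 4 (0.10 log units; within the scatter). Compound 4 is estimated at 0.05 nM, within a range of 0.015 nM to 0.16 nM.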

Compound 4, inhibition constant: 0.1 nM
For compound 4 the middle estimate is 2.0-fold (0.30 log units) below the measured one; the measured number falls inside the stated range.
By their numbers in this assay, from the lowest: compounds 2 and 1 (each within the scatter of the next); then compound 4; then compound 3.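

In this assay the amide-type nitrogen in the ring now has its first counted step, and the exchange of pyrimidin-5-yl for pyridin-3-yl gives a 2.5-fold higher number from compound 1 to compound 4 (0.40 log units; beyond the scatter) in the shared core. This position therefore does not tolerate every change of aromatic ring without effect: both groups have the same count of heavy atoms, yet a six-membered aromatic ring with 1 hetero atom in place of one with 2 hetero atoms moves the number beyond the scatter. No measurement at hand bears on the reason for this step.

On these data alone, this is a single pair, so it remains open whether the exchange gives a step of similar size when the rest of the core differs. Also open, as far as these compounds go, is how pyridin-4-yl, pyrimidin-2-yl or unsubstituted phenyl on that nitrogen would compare with pyrimidin-5-yl.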